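Fluorine on the Phenyl Ring and Transporter Inhibition

The source may report more compounds than this note shows. Statements on the series, on what has been measured and on what is new or still open speak of the compounds shown alone.

Compound 1 `N[C@H](C(=O)O)C(Cc1ccccc1)C(=O)O` is examined in an in vitro assay on cells for inhibition of excitatory amino acid transporter 3 (Homo sapiens), tested at 100 uM; a lower number here means less inhibition, a higher number more inhibition at the concentration tested (going by the name of the read-out). In this assay compound 1 gives 4%, the higher of the two numbers measured, with compound 2 `N[C@H](C(=O)O)C(Cc1cccc(F)c1)C(=O)O` nearest at 0%. The step of a number 4 percentage points lower from compound 1 to compound 2 (within the scatter) lies within the scatter. Compound 3 `N[C@H](C(=O)O)C(Cc1ccc(F)cc1)C(=O)O` carries fluoro in place of hydrogen on an aromatic carbon. For the measured compounds named here, the only measured step that bears on this change, a number 4 percentage points lower from compound 1 to compound 2 (within the scatter), was within the scatter, so no step beyond the scatter is expected in this assay. For compound 3 the expected step is a number 1 percentage points lower from compound 1 to compound 3 (within the scatter). Compound 3 is therefore estimated at 3%, in a range from -7% to 13%.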

Compound 3, a percentage reported as inhibition, at one concentration (the size of the read-out at that concentration, not a potency): 7%
For compound 3 the middle estimate is 4 percentage points below the measured one, within the range that was stated.
By their numbers in this assay, from the lowest: compounds 2, 1 and 3 (each within the scatter of the next).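

In this assay, for the compounds shown here, fluoro on an aromatic carbon para to a large group comes with a number 3 percentage points higher from compound 1 to compound 3 (within the scatter), so this place, like the one in compound 2, gives no step beyond the scatter. No measurement is available that bears on why the numbers fall as they do.

Still open, from the compounds shown here alone, is whether a group other than fluoro, such as chloro, methoxy or trifluoromethyl, would move the number beyond the scatter at this place. The compounds shown also do not tell what an amine or a carboxylic acid on the ring would do.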